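Lengthening the Chain to Piperazine in Compound 1

A few compounds are considered here, and "the series" means these few. Any claim that something is new, unique, unknown or untested is made for them only; others in the source may bear on it.

Measured compounds:
compound 1 `c1ccc2c(c1)CN[C@@H](CN(CCCN1CCNCC1)[C@H]1CCCc3cccnc31)C2`: 100%
compound 2 `c1cnc2c(c1)CN[C@H](CN(CCCN1CCNCC1)[C@H]1CCCc3cccnc31)C2`: 100%
compound 3 `c1cnc2c(c1)CCC[C@@H]2N(CCCN1CCNCC1)Cc1nc2ccccc2s1`: 50%

In an ADME assay on microsomes from liver (Homo sapiens) for metabolic stability, read by LC-MS, with a stated time of 10 min, tested at 0.5 uM (on this read-out lower numbers stand for a less stable compound and higher numbers for a more stable compound), compound 1 gives 100%, level with compound 2 and together with it the highest of the three values. The step of no change at the digits printed from compound 1 to compound 2 (within the scatter) shows no change, while a number 50 percentage points lower from compound 1 to compound 3 (beyond the scatter) and a number 50 percentage points lower from compound 2 to compound 3 (beyond the scatter) are large drops.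

Compound 4 `c1ccc2c(c1)CN[C@@H](CN(CCCCN1CCNCC1)[C@H]1CCCc3cccnc31)C2` differs from compound 1 by (piperazin-1-yl)methyl in place of piperazin-1-yl on a saturated chain carbon, three bonds along the chain from an amine nitrogen. For the measured compounds named here, none of the measured steps concerns the chain between the amine nitrogen and the piperazine: the measured steps swap the ring group on the other side of that nitrogen. The shared core of compound 1 is kept. Going by the values given here, with no directly relevant step, the expectation is for no change beyond the scatter in this assay, so compound 4 is estimated at 92%, with a range from 75% to 100%. This estimate means an expected step of a number 8 percentage points lower from compound 1 to compound 4 (within the scatter).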

Compound 4, percent of the compound remaining: 82%
Compound 4: the middle estimate sits 10 percentage points above what was measured; low and high end bracket the measured number.
By their numbers in this assay, from the lowest: compound 3; then compound 4; then compounds 1 and 2 (each within the scatter of the next).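

For the compounds shown here, the earlier compounds changed only the ring group on the other side of the amine nitrogen, so this is the first view of the chain that carries the piperazine. In this assay, (piperazin-1-yl)methyl in place of piperazin-1-yl gives a number 18 percentage points lower from compound 1 to compound 4 (beyond the scatter), showing that one added chain carbon is enough to move the read-out beyond the scatter, although this modest step is smaller than the large one seen in a number 50 percentage points lower from compound 1 to compound 3 (beyond the scatter). Nothing available gives a reason for this drop.

The compounds shown leave open whether a longer chain, such as 4-(piperazin-1-yl)butyl, would lower the number further or leave it level. They also do not tell whether morpholine in place of the piperazine would change the picture, or whether the added carbon would have a similar effect on compound 2.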